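The source may hold more compounds than are shown below. What is called first, only, known or untested is meant among the compounds shown, and "the series" means these compounds.

Compound 1 `Nc1nc(-c2ccccc2)nc2sc(-c3ccco3)nc12`: 15 nM
Compound 2 `Nc1nc(-c2cccc(O)c2)nc2sc(-c3ccco3)nc12`: 15.7 nM

Both compounds were tested in an assay on CHO cells for displacement of a labelled ligand from adenosine receptor A3 (Homo sapiens), read by scintillation counting, with a stated time of 3 h; a higher number here means a weaker inhibitor, a lower number a stronger inhibitor. There compound 1 gives 15 nM and compound 2 gives 15.7 nM. Among the measured compounds shown here, the single measured step, a 1.0-fold higher number from compound 1 to compound 2 (0.02 log units; within the scatter), lies within the scatter, so compound 2 and compound 1 cannot be told apart on these numbers.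

Compound 3 `Cc1ccc(-c2nc(N)c3nc(-c4ccco4)sc3n2)o1` has not yet been measured. It differs from compound 2 in one place: 5-methylfuran-2-yl in place of 3-hydroxyphenyl on an aromatic carbon. For the measured compounds named here, the only step measured so far concerns a hydroxy group added to a ring that stays in place, whereas here the whole ring is exchanged for a different one, so that step bears on the change only loosely. With nothing pointing either way, the step from compound 2 to compound 3 in this assay is expected to be small, a 1.3-fold higher number from compound 2 to compound 3 (0.11 log units; within the scatter). Compound 3 is therefore estimated at 20 nM, with a range from 5 nM to 80 nM.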

Compound 3, inhibition constant: 13.8 nM
Beside the measured number, compound 3's estimate is 1.4-fold (0.16 log units) above it, and the stated range covers the measured number.
By their numbers in this assay, from the lowest: compounds 3, 1 and 2 (each within the scatter of the next).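

Among the compounds shown here, until now, the only change tested was a hydroxy group on a ring that stayed in place. Here the whole ring on the aromatic carbon between two ring nitrogen atoms is exchanged, and this assay shows a 1.1-fold lower number from compound 2 to compound 3 (0.06 log units; within the scatter) and a 1.1-fold lower number from compound 1 to compound 3 (0.04 log units; within the scatter), so 5-methylfuran-2-yl, a five-membered aromatic ring with 1 hetero atom, cannot be told apart from either 3-hydroxyphenyl or phenyl at this position. Nothing available explains why these exchanges leave the number within the scatter.

From the compounds shown here alone, all three compounds carry an aromatic ring at this position, so the effect of an open butyl chain, or of a ring bearing an amine or a carboxylic acid, remains open. Also open is what the methyl group of 5-methylfuran-2-yl contributes, as the compounds shown do not separate it from its ring.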